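Closing a Ring on the Nitrogen Chain

A few compounds are considered here, and "the series" means these few. Any claim that something is new, unique, unknown or untested is made for them only; others in the source may bear on it.

Compound 3 `CCCCn1ccc(N2CCC(c3ccccc3)CC2)c(C#N)c1=O` gives the largest maximal response of the three measured compounds in a functional assay on CHO cells for positive allosteric modulation of metabotropic glutamate receptor 2 (Homo sapiens), with a stated time of 30 min (on this read-out higher numbers stand for larger maximal responses and lower numbers for smaller maximal responses), reaching 309%. Compound 2 `CC(C)CCn1ccc(CCc2ccccc2)c(C#N)c1=O` reaches 168% and compound 1 `CC(C)CCn1ccc(-c2ccccc2)c(C#N)c1=O` reaches 135%; both of their gaps to compound 3 lie beyond the scatter. Compound 4 `N#Cc1c(N2CCC(c3ccccc3)CC2)ccn(CC2CCC2)c1=O` has not yet been measured in this assay. It differs from compound 3 in a single place: cyclobutyl in place of propyl on a saturated chain carbon bound to an aromatic nitrogen. Going by the values given here, no measured pair isolates this change, so the data show nothing about its effect on the maximal response. The step of a number 9 percentage points lower from compound 3 to compound 4 (within the scatter) is expected to be small, in either direction, and likely to remain within the scatter. Compound 4 is therefore estimated at 300%, with a range from 230% to 370%.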

Compound 4, largest response reached (Emax), in percent of the reference or control that the assay uses: 269%
The estimate for compound 4 lay 31 percentage points above the measured number; low and high end bracket the measured number.
By their numbers in this assay, from the lowest: compound 1; then compound 2; then compound 4; then compound 3.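

Going by these compounds alone, the step of a number 40 percentage points lower from compound 3 to compound 4 (beyond the scatter) in this assay is the first measured change at this position, a saturated chain carbon bound to an aromatic nitrogen. Read one bond further out, butyl gives way to cyclobutylmethyl, and closing that ring costs maximal response, though compound 4 keeps a large response of 269% in this single pair. No available evidence bears on the reason for this step. Still open, as far as these compounds go, is whether cyclopropylmethyl or an open pentyl chain would hold the response of compound 3 or lose it as cyclobutyl does.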